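The source may hold more compounds than are shown below. What is called first, only, known or untested is meant among the compounds shown, and "the series" means these compounds.

In an ADME assay on cells (Hepatocyte, Homo sapiens) for metabolic stability, with a stated time of 30 min (on this read-out lower numbers stand for a less stable compound and higher numbers for a more stable compound), compound 1 `CS(=O)(=O)NC1CCC(CN2CCN(c3cc(=O)c4cc(C(F)(F)F)cc([N+](=O)[O-])c4s3)CC2)CC1` gives 105%, compound 2 `O=c1cc(N2CCN(CC3CCCCC3)CC2)sc2c(NO)cc(C(F)(F)F)cc12` gives 19.1% and compound 3 `Nc1cc(C(F)(F)F)cc2c(=O)cc(N3CCN(CC4CCC(O)CC4)CC3)sc12` gives 72.9%. Compound 3 therefore sits second of the three, below compound 1 and above compound 2, with both gaps beyond the scatter. Compound 4 `Nc1cc(C(F)(F)F)cc2c(=O)cc(N3CCN(CC4CCCCC4)CC3)sc12` has hydrogen in place of hydroxy on a saturated ring carbon, so (4-hydroxycyclohexyl)methyl becomes cyclohexylmethyl (hydrogen in place of hydroxy on a saturated ring carbon). Among the compounds with values here, no measured pair isolates this change, so any forecast is uncertain. Compound 2 also carries cyclohexylmethyl and gives 19.1%, although it differs elsewhere in the structure. A moderate fall beyond the scatter is expected, a number 27.9 percentage points lower from compound 3 to compound 4 (beyond the scatter). The estimate for compound 4 is 45%, within an expected range of 20% to 70%.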

Compound 4, percent of the compound remaining: 0.9%
Beside the measured number, compound 4's estimate is 44.1 percentage points above it; the whole stated range lies above it.
By their numbers in this assay, from the lowest: compound 4; then compound 2; then compound 3; then compound 1.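

In this assay, within the data shown here, the single hydroxy on the saturated ring carbon, three ring bonds from the ring atom that bears a large group, turns out to matter greatly: hydrogen in its place gives a number 72 percentage points lower from compound 3 to compound 4 (beyond the scatter) in the first clean comparison at this position. The same swap on a nitrogen on an aromatic ring gives a number 18.2 percentage points lower from compound 2 to compound 4 (beyond the scatter) and so also lowers the number, by less. No measurement here explains either fall. As far as these compounds go, whether a methoxy group or a fluorine atom on that ring carbon would hold the number up as hydroxy does remains open.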